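A few compounds are considered here, and "the series" means these few. Any claim that something is new, unique, unknown or untested is made for them only; others in the source may bear on it.

Compound 1, `COc1ccc(-c2nc3c(C(=O)Nc4ccccc4F)cccc3[nH]2)c(OC)c1OC`, in an ADME assay on Vero cells (Chlorocebus sabaeus) for cytotoxicity (on this read-out higher numbers stand for lower toxicity in this test and lower numbers for higher toxicity in this test), gives 37.8 uM.
Compound 2, `CCC(CC)NC(=O)c1cccc2[nH]c(-c3ccc(OC)c(OC)c3OC)nc12`, in this assay gives 32.3 uM.

Only these two measurements exist, so compound 2 stands alongside compound 1: the step of a 1.2-fold lower number from compound 1 to compound 2 (0.07 log units; within the scatter) is too small to count as a real change, and the two compounds cannot be told apart on this read-out. Compound 3, `COc1ccc(-c2nc3c(C(=O)Nc4nc5ccccc5[nH]4)cccc3[nH]2)c(OC)c1OC`, has not yet been measured. Its difference from compound 2 is 1H-benzimidazol-2-yl in place of pentan-3-yl on an amide-type nitrogen. Among the compounds with values here, the one measured step that bears on an exchange at this amide-type nitrogen is a 1.2-fold lower number from compound 1 to compound 2 (0.07 log units; within the scatter), where a 2-fluorophenyl group gave way to pentan-3-yl without moving the number beyond the scatter. Compound 3 brings a ring group back to the same place, so the nearest comparisons are compound 1 and compound 2 alike, and both sit close together. For compound 3 the expectation is therefore no step beyond the scatter, and the estimated step is a 1.1-fold higher number from compound 2 to compound 3 (0.03 log units; within the scatter). For compound 3 in this assay the estimate is 35 uM, with a range from 15 uM to 80 uM.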

Compound 3, half-maximal toxic concentration: 29 uM
For compound 3 the middle estimate is 1.2-fold (0.08 log units) above the measured one; the range from low to high includes it.
By their numbers in this assay, from the lowest: compounds 3, 2 and 1 (each within the scatter of the next).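

Placing 1H-benzimidazol-2-yl on the amide-type nitrogen gives, in this assay, a 1.1-fold lower number from compound 2 to compound 3 (0.05 log units; within the scatter) and a 1.3-fold lower number from compound 1 to compound 3 (0.12 log units; within the scatter), and both steps lie within the scatter, so the three compounds cannot be told apart on this read-out. This extends what the first pair showed: the entering group has 9 heavy atoms against 5 for pentan-3-yl, two aromatic rings, a hydrogen-bond donor and a hydrogen-bond acceptor, yet even this exchange produces no real change in the number, so an open branched chain, a fluorinated phenyl ring and a two-ring group all read alike at this place. No evidence is available to explain why the read-out stays flat across these three groups.

The compounds shown leave open whether a group bearing a carboxylic acid or an amine, or a longer chain, on this nitrogen would move the number beyond the scatter. The rest of the molecule is the same in all three compounds, so they also leave open whether a change elsewhere on the shared core would shift this read-out.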